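Ethylamino to dimethylamino swap carried onto a second core

A few compounds are considered here, and "the series" means these few. Any claim that something is new, unique, unknown or untested is made for them only; others in the source may bear on it.

Compound 1 `CCNCC(=O)Nc1cc(OC)ccc1C(=O)c1ccc(OC)c2c1C=CC(C)(C)O2` is the starting point on the first core; in a functional assay on HCT-8 cells (Homo sapiens) for antiproliferative activity, read by MTT assay, with a stated time of 48 h (a lower number here means a stronger inhibitor, a higher number a weaker inhibitor), compound 1 gives 7890 nM. Its partner compound 3 `COc1ccc(C(=O)c2ccc(OC)c3c2C=CC(C)(C)O3)c(NC(=O)CN(C)C)c1` carries the change dimethylamino in place of ethylamino on a saturated chain carbon bound to a carbonyl carbon and in this assay compound 3 gives 5660 nM. The step measured for this change is a 1.4-fold lower number from compound 1 to compound 3 (0.14 log units; within the scatter), so the two compounds are not separated beyond the usual scatter.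

Compound 2 `CCNCC(=O)Nc1cc(OC)ccc1C(=O)c1ccc2c(c1)C=CC(C)(C)O2` sits on the second core and in this assay compound 2 gives 3990 nM. The difference between the core of compound 2 and the core of compound 1 is not broken down here; the two values of compound 1 and compound 2 lie within the scatter of each other, as do those of compound 2 and compound 3.

Compound 4 `COc1ccc(C(=O)c2ccc3c(c2)C=CC(C)(C)O3)c(NC(=O)CN(C)C)c1` has not been measured. It stands to compound 2 as compound 3 stands to compound 1: the change is dimethylamino in place of ethylamino on a saturated chain carbon bound to a carbonyl carbon, at the same place in both pairs, so it is the same change carried onto the second core. Among the measured compounds shown here, the only guide is the single measured step, a 1.4-fold lower number from compound 1 to compound 3 (0.14 log units; within the scatter), which is within the scatter. The step expected in this assay is therefore a 1.3-fold lower number from compound 2 to compound 4 (0.12 log units; within the scatter), beside the earlier one, resting on compound 1 and compound 3 alone. Compound 4 is accordingly expected to give about 3000 nM in this assay, estimated to fall between 1200 nM and 7500 nM.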

Compound 4, half-maximal inhibitory concentration: 2420 nM
For compound 4 the middle estimate is 1.2-fold (0.09 log units) above the measured one; measured number inside the range.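

In this assay, dimethylamino in place of ethylamino on the core of compound 2 gives a 1.6-fold lower number from compound 2 to compound 4 (0.22 log units; within the scatter), so this pair, like the pair on the core of compound 1, is not separated beyond the usual scatter. The two steps agree, and the change carries from one core to the other with no measurable difference in its size: the same change on two cores in this assay, a 1.4-fold lower number (0.14 log units; within the scatter) from compound 1 to compound 3 and a 1.6-fold lower number (0.22 log units; within the scatter) from compound 2 to compound 4, 1.2-fold (0.07 log units) apart, within the scatter of two such steps

Among the compounds shown here, this shows only that the swap leaves the antiproliferative read-out within the scatter on both cores; although both steps point to a lower number, neither one establishes a real gain for dimethylamino over ethylamino, and two pairs give no rule for other cores or for other changes at this place.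

The compounds shown leave open whether any amine on this saturated chain carbon matters at all, since a primary amine, diethylamino, pyrrolidine or morpholine could show a step beyond the scatter where ethylamino and dimethylamino do not. Also open, as far as these compounds go, is how either core would respond to a longer chain carrying the amine, or to a carboxylic acid in place of the amine.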